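A few compounds are considered here, and "the series" means these few. Any claim that something is new, unique, unknown or untested is made for them only; others in the source may bear on it.

Measured compounds:

Compound 1 `FC1(F)CCC(NCc2ccc(CN(C[C@H]3Cc4ccccc4CN3)[C@H]3CCCc4cccnc43)cc2)CC1`: in a functional assay on cells for agonist activity at C-X-C chemokine receptor type 4 (Homo sapiens), read by fluorescence and calcium flux, with a stated time of 90 s (a higher number here means that more compound is needed for the effect, a lower number that less compound is needed), compound 1 gives > 30000 nM, which is a limit of the assay and not a number.
Compound 2 `c1ccc2c(c1)CN[C@@H](CN(Cc1ccc(CNC3CCOCC3)cc1)[C@H]1CCCc3cccnc31)C2`: in this assay compound 2 gives > 30000 nM, again a limit and not a number.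
Compound 3 `CC(C)(CCN(C[C@H]1Cc2ccccc2CN1)[C@H]1CCCc2cccnc21)CNC1CCC(F)(F)CC1`: in this assay compound 3 gives > 30000 nM, also a limit and not a number.

Compounds 1 and 2 differ in one place, (oxan-4-yl in place of 4,4-difluorocyclohexyl on an amine nitrogen). The step between them, a step that the two limits leave unreadable from compound 1 to compound 2, cannot be read because the limit of > 30000 nM in this assay, at which 3 of the 3 values shown sit: both values sit at the same limit, so nothing is known about the direction or the size of the change.

Compound 3 carries a different core; the difference between the two cores is not broken down here. Among the compounds with values here, the three measured values show only that none of the compounds reaches the effect within the range of the assay.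

Compound 4 `CC(C)(CCN(C[C@H]1Cc2ccccc2CN1)[C@H]1CCCc2cccnc21)CNC1CCOCC1` is not yet measured. It differs from compound 3 by oxan-4-yl in place of 4,4-difluorocyclohexyl on an amine nitrogen, the same change as that between compounds 1 and 2, at the same kind of place, word for word.

For this assay the step from compound 3 to compound 4 is expected to be a step that the limit leaves unreadable from compound 3 to compound 4, which rests on the unreadable step from compound 1 to compound 2 and on the limit of compound 3, > 30000 nM. Compound 4 is expected to give about 60000 nM, within 20000 nM to 300000 nM, with a high chance that the assay again reports only a limit.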

Compound 4, half-maximal effective concentration: > 30000 nM
Compound 4 was reported as a limit (the forecaster's own chance of this, stated with the estimate: 85%); the middle value is on the limit's open side.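

No step can be read from compound 3 to compound 4, any more than from compound 1 to compound 2, because all four values are limits of the assay and not numbers: the limit of > 30000 nM in this assay, at which 4 of the 4 values shown sit.
In this assay the compounds shown leave open whether any of them reaches the effect at all, and whether oxan-4-yl in place of 4,4-difluorocyclohexyl on an amine nitrogen changes the concentration needed for it.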